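Moving the hydroxyl from 4-hydroxypiperidin-1-yl to 3-hydroxypiperidin-1-yl

The compounds below may be only part of what the source reports. "The series", "measured", "known", "first", "only" and "open" are said of these compounds alone.

Compound 1 `CCC(=O)N1CCC(S(=O)(=O)c2ccc(CNC(=O)N3Cc4ccncc4C3)cc2)CC1`: 216000 nM
Compound 2 `O=C(NCc1ccc(S(=O)(=O)N2CCC(O)CC2)cc1)N1Cc2ccncc2C1`: 174000 nM

In a physicochemical assay for solubility, in phosphate buffer, with a stated time of 24 h, at pH 7.4, tested at 100 uM (on this read-out higher numbers stand for higher solubility and lower numbers for lower solubility), compound 2 gives 174000 nM and compound 1 gives 216000 nM. Among the compounds with values here, these two numbers lie within the usual scatter of each other, so they set no order between the compounds, and compound 2 stands level with the only other measured compound.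

Compound 3 `O=C(NCc1ccc(S(=O)(=O)N2CCC[C@H](O)C2)cc1)N1Cc2ccncc2C1` has not yet been measured. It carries 3-hydroxypiperidin-1-yl in place of the 4-hydroxypiperidin-1-yl of compound 2 on a sulfonyl sulfur: 3-hydroxypiperidin-1-yl in place of 4-hydroxypiperidin-1-yl on a sulfonyl sulfur. The two compounds have the same atoms, joined differently.

Within the data shown here, no measured step covers this exact change. The nearest evidence is a different replacement on the same sulfonyl sulfur, 4-hydroxypiperidin-1-yl in place of 1-propanoylpiperidin-4-yl. Because of a 1.2-fold lower number from compound 1 to compound 2 (0.09 log units; within the scatter) no step beyond the scatter is expected in this assay, and neither direction is favoured. The expected step is small: a 1.0-fold lower number from compound 2 to compound 3 (0.01 log units; within the scatter). Compound 3 is estimated at 170000 nM, with an expected range from 90000 nM to 280000 nM.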

Compound 3, solubility: 215000 nM
Compound 3: middle estimate off by 1.3-fold (0.10 log units), on the low side, within the range that was stated.
By their numbers in this assay, from the lowest: compounds 2, 3 and 1 (each within the scatter of the next).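

In this assay, 3-hydroxypiperidin-1-yl in place of 4-hydroxypiperidin-1-yl on a sulfonyl sulfur gives a 1.2-fold higher number from compound 2 to compound 3 (0.09 log units; within the scatter), so this exchange between two groups with the same atoms, joined differently, sets no order between compound 2 and compound 3, and the defined stereocentre that enters with 3-hydroxypiperidin-1-yl brings no step beyond the scatter. The replacement of 1-propanoylpiperidin-4-yl by 3-hydroxypiperidin-1-yl at the same place gives a 1.0-fold lower number from compound 1 to compound 3 (0.00 log units; within the scatter), so all three groups shown on the sulfonyl sulfur now stand level with one another in this assay, a statement that holds for these three compounds only. No independent measurement bears on this result, and nothing shown accounts for it.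

The compounds shown leave open whether a group of a different kind on the sulfonyl sulfur, such as an amine or a carboxylic acid, would give a step beyond the scatter in this assay. They also leave open whether the mirror-image form of 3-hydroxypiperidin-1-yl would stand level with the form carried by compound 3.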